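Liver microsome stability: methyl to isopropyl on the core

The source may report more compounds than this note shows. Statements on the series, on what has been measured and on what is new or still open speak of the compounds shown alone.

compound 1 `Cc1c([C@H](OC(C)(C)C)C(=O)O)c(N2CCC(C)(C)CC2)c(-c2ccc(OCCc3ccc(F)cc3)cc2)c2nccn12` in an ADME assay on microsomes from liver (Rattus norvegicus) for metabolic stability; on this read-out lower numbers stand for a shorter-lived compound and higher numbers for a longer-lived compound: > 2 h
compound 2 `CCc1cn2c(C)c([C@H](OC(C)(C)C)C(=O)O)c(N3CCC(C)(C)CC3)c(-c3ccc(OCCc4ccc(F)cc4)cc3)c2n1` in this assay: > 2 h

For compound 2 the value > 2 h is a limit of the assay, not a number. Within the data shown here, the step that the two limits leave unreadable from compound 1 to compound 2 is therefore unreadable; the only evidence is the limit of > 2 h in this assay, at which 2 of the 2 values shown sit. Compound 3 `Cc1c([C@H](OC(C)(C)C)C(=O)O)c(N2CCC(C)(C)CC2)c(-c2ccc(OCCc3ccc(F)cc3)cc2)c2nc(CC(C)C)cn12` differs from compound 2 by isopropyl in place of methyl on a saturated chain carbon bound to an aromatic carbon. Among the measured compounds shown here, no measured step bears on that change in size. In this assay compound 3 is expected to reach the same limit, with an estimated step that the limit leaves unreadable from compound 2 to compound 3 that is not readable beyond the scatter. The estimate for compound 3 is 2.5 h, from 1 h to 6 h.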

Compound 3, half-life: > 2 h
Compound 3: no number, only a limit (the forecaster's own chance of this, stated with the estimate: 80%); the middle value lies beyond the limit too.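

In this assay compound 3 gives > 2 h as a limit of the assay, not a number. No step among compound 1, compound 2 and compound 3 can be read: the limit of > 2 h in this assay, at which 3 of the 3 values shown sit.

As far as these compounds go, the true half-lives of all three compounds, and so any effect of the changed groups, remain open.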